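The source may hold more compounds than are shown below. What is called first, only, known or untested is meant among the compounds shown, and "the series" means these compounds.

Series in a functional assay for inhibition, with Rattus norvegicus as the target; a lower number here means a stronger inhibitor, a higher number a weaker inhibitor:
Compound 1 `CC(C)(C)C/N=c1\c(O)c(O)\c1=N/c1ccc(C#N)cc1`: > 30000 nM (a limit)
Compound 2 `CC(C)/N=c1\c(O)c(O)\c1=N/c1ccc(C#N)cc1`: 13700 nM
Compound 3 `C/N=c1\c(O)c(O)\c1=N/c1ccc(C#N)cc1`: > 30000 nM (a limit)
Compound 4 `CCCCCCC/N=c1\c(O)c(O)\c1=N/c1ccc(C#N)cc1`: not yet measured

Compound 3 stands only at a limit of the assay, > 30000 nM, and not at a number. Across the series, the relevant record is the limit of > 30000 nM in this assay, at which 2 of the 3 values shown sit. Compound 4 carries hexyl in place of hydrogen on a saturated chain carbon bound to a double-bonded nitrogen. The same difference reads methyl to heptyl.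

Two measured steps change the group on that nitrogen. One is an at least 2.1-fold higher number from compound 2 to compound 3 (0.34 log units; beyond the scatter), with methyl in place of isopropyl. The other is an at least 2.1-fold lower number from compound 1 to compound 2 (0.34 log units; beyond the scatter), with isopropyl in place of neopentyl. Both are bounded steps of at least modest size, and they run in opposite directions as the group grows from methyl to neopentyl. Going by the values given here, no measured compound carries a chain as long as heptyl, so these steps are only a loose guide.

Among the compounds with values here, compound 2 gives the sole number, 13700 nM. Compound 4 is expected to lie nearer the limit of the assay than compound 2 does, possibly reporting only a limit. The step expected is small and of uncertain direction: an at least 1.3-fold lower number from compound 3 to compound 4 (0.13 log units; that floor lies within the scatter). The estimate for compound 4 is 22000 nM, with an expected range of 6000 nM to 60000 nM.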

Compound 4, half-maximal inhibitory concentration: > 30000 nM
Compound 4 ended at the assay's limit; the forecaster's own chance of this, stated with the estimate: 50%; middle value at least 1.3-fold (0.13 log units) from the limit.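

In this assay, the change from isopropyl to heptyl on the double-bonded nitrogen gives an at least 2.1-fold higher number from compound 2 to compound 4 (0.34 log units; beyond the scatter). Going by these compounds alone, the longest chain therefore shows no gain over isopropyl, and compound 2 remains the only compound with a numbered value, while the others sit at one limit: the limit of > 30000 nM in this assay, at which 3 of the 4 values shown sit. The steps linking compound 4 to compound 1 and to compound 3 cannot be read, as both ends of each are limits, so heptyl cannot be ordered against methyl or neopentyl.

Going by these compounds, how an ethyl, propyl, butyl or cyclopentyl group would read on that nitrogen stays open, and with it whether the numbered value at isopropyl reflects a narrow range of chain length or branching at the carbon bound to the nitrogen. Also open, on these data alone, are how far compound 1, compound 3 and compound 4 lie past the limit, and whether a heptyl chain ending in an amine or a carboxylic acid would return a numbered value.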